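Purine ribosides as equilibrative nucleoside transporter 1 inhibitors

The source may report more compounds than this note shows. Statements on the series, on what has been measured and on what is new or still open speak of the compounds shown alone.

Within this small set, compound 1 `OC[C@H]1O[C@@H](n2cnc3c(SCC4CCCCC4)ncnc32)[C@H](O)[C@@H]1O` gives the lowest number: in an assay on isolated protein for binding affinity to Equilibrative nucleoside transporter 1 (Homo sapiens) (a lower number here means a stronger inhibitor, a higher number a weaker inhibitor), compound 1 gives 1550 nM. Compound 3 `CSc1ncnc2c1c(Br)cn2[C@@H]1O[C@H](CO)[C@@H](O)[C@H]1O` gives 115000 nM and compound 2 `CSc1ncnc2c1ncn2C1CCCCO1` gives 275000 nM, both well beyond the scatter from compound 1, which is thus the strongest inhibitor here.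

Compound 4 `OC[C@H]1O[C@@H](n2cnc3c(CSc4cccc(I)c4)ncnc32)[C@H](O)[C@@H]1O` is not yet measured. It differs from compound 1 in one place: a group of 9 heavy atoms (7 carbon, 1 sulfur, 1 iodine; one six-membered aromatic ring of carbon only) in place of a group of 8 heavy atoms (7 carbon, 1 sulfur; one six-membered non-aromatic ring of carbon only), on an aromatic carbon. Among the measured compounds shown here, no measured pair shows this exact change, so the size of the step is uncertain; a moderate gain is expected, in the direction of a lower number, rather than a change within the scatter. Compound 4 is estimated at 500 nM, in a range from 100 nM to 3000 nM, which would mean a step of a 3.1-fold lower number from compound 1 to compound 4 (0.49 log units; beyond the scatter) in this assay.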

Compound 4, half-maximal inhibitory concentration: 245 nM
Compound 4: the middle estimate sits 2.0-fold (0.31 log units) above what was measured; the measured number falls inside the stated range.
By their numbers in this assay, from the lowest: compound 4; then compound 1; then compound 3; then compound 2.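

Replacing (cyclohexylmethyl)sulfanyl with the iodine-bearing aromatic group gives a 6.3-fold lower number from compound 1 to compound 4 (0.80 log units; beyond the scatter) in this assay and shows that this position, on an aromatic carbon next to the ring nitrogen, accepts a six-membered aromatic ring of carbon only in place of a non-aromatic one, with a gain beyond the scatter. Among the compounds shown here, the single step changes the ring and adds iodine together, so neither can be credited alone. Nothing available bears on the reason for the gain. Still open, going by these compounds, is whether the aromatic ring without iodine keeps this gain, and how an amine or a carboxylic acid on that ring would fare.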